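Replacing Chloro With Methoxy After a Longer Chain

The compounds below may be only part of what the source reports. "The series", "measured", "known", "first", "only" and "open" are said of these compounds alone.

Compound 1 `CCCCC(CCO)n1cnc2c(Cl)ncnc21` and compound 2 `CCCCC(CCO)n1cnc2c(OC)ncnc21` share one core, while compound 3 `CCCCCCCCC(CCO)n1cnc2c(Cl)ncnc21` differs from compound 1 by butyl in place of hydrogen on a saturated chain carbon, five bonds along the chain from an aromatic nitrogen. In a functional assay on HCT-116 cells (Homo sapiens) for antiproliferative activity, read by MTT assay, with a stated time of 48 h (a higher number here means a weaker inhibitor, a lower number a stronger inhibitor), compound 1 gives > 50000 nM, which is a limit of the assay rather than a number. In this assay compound 2 gives > 50000 nM, again a limit. Within the data shown here, compound 3 gives 1650 nM, the only real number among the three, and the step of an at least 30-fold lower number from compound 1 to compound 3 (1.48 log units; beyond the scatter) is large. The change from compound 1 to compound 2 is methoxy in place of chloro on an aromatic carbon; its size, a step that the two limits leave unreadable from compound 1 to compound 2, cannot be read, since both values sit at the limit (the limit of > 50000 nM in this assay, at which 2 of the 3 values shown sit). Compound 4 `CCCCCCCCC(CCO)n1cnc2c(OC)ncnc21` has not been measured; it differs from compound 3 by methoxy in place of chloro on an aromatic carbon, the same change in the same place. The earlier instance of this change gives no readable size, so the expectation for compound 4 rests on compound 3 alone and is uncertain. The step of a 2.4-fold higher number from compound 3 to compound 4 (0.38 log units; beyond the scatter) is expected to be small, resting on compound 3 and its value 1650 nM. Compound 4 is estimated at 4000 nM, plausibly between 1500 nM and 50000 nM.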

Compound 4, half-maximal inhibitory concentration: 12800 nM
Beside the measured number, compound 4's estimate is 3.2-fold (0.51 log units) below it; measured number inside the range.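

In this assay, methoxy in place of chloro gives a 7.8-fold higher number from compound 3 to compound 4 (0.89 log units; beyond the scatter), the only readable size for this change, since on the core of compound 1 the step cannot be read. Butyl in place of hydrogen on the saturated chain carbon gives an at least 3.9-fold lower number from compound 2 to compound 4 (0.59 log units; beyond the scatter), so the number falls with chloro and with methoxy on the ring, and the two instances of this change stand as follows: the same change on two cores in this assay, an at least 30-fold lower number (1.48 log units; beyond the scatter) from compound 1 to compound 3 and an at least 3.9-fold lower number (0.59 log units; beyond the scatter) from compound 2 to compound 4; the limit leaves it open whether they differ. Compound 2 gives > 50000 nM, a limit and not a number, and so no size for either change can yet be compared from one core to the other.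

The compounds shown leave open whether methoxy in place of chloro would give a similar step on a chain of some other length, such as one longer than that of compound 4. They also leave open what an amine or an ethoxy group in the place of chloro would give, or a carboxylic acid at the end of the chain in place of the hydroxyl.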